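The source may report more compounds than this note shows. Statements on the series, on what has been measured and on what is new or still open speak of the compounds shown alone.

Of the compounds shown here, three built on a shared core have been read in a functional assay on MDA-MB-231 cells (Homo sapiens) for inhibition, read by MTT assay, with a stated time of 24 h; on this read-out lower numbers stand for stronger inhibition of growth and higher numbers for weaker inhibition of growth. In that assay, compound 1 (`CC(C)[C@H](N)C(=O)OC[C@H]1O[C@@H](n2cc(F)c(=O)[nH]c2=O)C[C@@H]1OC(=O)[C@@H](N)C(C)C`) gives 31700000 nM, compound 2 (`N[C@@H](CCC(=O)O[C@H]1C[C@H](n2cc(F)c(=O)[nH]c2=O)O[C@@H]1CO)C(=O)O`) gives 34900000 nM and compound 3 (`N[C@@H](CC(=O)O[C@H]1C[C@H](n2cc(F)c(=O)[nH]c2=O)O[C@@H]1CO)C(=O)O`) gives 37600000 nM, which places compound 3 within the scatter of both other compounds. Compound 4 (`CC(C)[C@H](N)C(=O)O[C@H]1C[C@H](n2cc(F)c(=O)[nH]c2=O)O[C@@H]1CO`) has not yet been measured. It departs from compound 3 in one place, with 1-amino-2-methylpropyl in place of 2-amino-2-carboxyethyl on a carbonyl carbon.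

Within the data shown here, no measured step covers this exchange directly. The closest evidence is a 1.1-fold higher number from compound 2 to compound 3 (0.03 log units; within the scatter), a change within the chain that leaves in compound 4, and that step stays within the scatter. Among the measured compounds shown here, compound 1, at 31700000 nM, also carries 1-amino-2-methylpropyl, although it differs from compound 4 in more than that group, and no single step links the two. With all three values lying so close together, the data give no sign of a large effect, and no step beyond the scatter is expected in this assay. The expected size of the change is an estimated 1.1-fold lower number from compound 3 to compound 4 (0.04 log units; within the scatter). The estimate for compound 4 is 34000000 nM, with an expected range from 22000000 nM to 52000000 nM.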

Compound 4, concentration for 50% growth inhibition: 32400000 nM
The estimate for compound 4 lay 1.0-fold (0.02 log units) above the measured number; the range from low to high includes it.
By their numbers in this assay, from the lowest: compounds 1, 4, 2 and 3 (each within the scatter of the next).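

In this assay, the exchange on the carbonyl carbon itself, 1-amino-2-methylpropyl in place of 2-amino-2-carboxyethyl, gives a 1.2-fold lower number from compound 3 to compound 4 (0.06 log units; within the scatter), so at this position a chain without the carboxylic acid stays level with one that carries it. The same holds against the other acid-bearing chain, since 1-amino-2-methylpropyl in place of 3-amino-3-carboxypropyl gives a 1.1-fold lower number from compound 2 to compound 4 (0.03 log units; within the scatter). Compound 4 also provides the single-place link to compound 1 that was missing before: hydrogen in place of (1-amino-2-methylpropyl)carbonyl on an oxygen on a saturated carbon gives a 1.0-fold higher number from compound 1 to compound 4 (0.01 log units; within the scatter), so that second ester leaves the reading within the scatter as well.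

Nothing among the results explains why these exchanges leave the reading so flat. Going by these compounds, whether a plain methyl group or a phenyl ring on this carbonyl carbon, with no amine at all, would step beyond the scatter stays open.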